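The compounds below may be only part of what the source reports. "The series", "measured", "known", "first", "only" and "open" are said of these compounds alone.

In an ADME assay on NHDF cells (Homo sapiens) for antiproliferative activity, with a stated time of 72 h (a lower number here means a stronger inhibitor, a higher number a weaker inhibitor), compound 1 (`CC(=O)Oc1ccccc1/C=C/c1nc2ccccc2c(=O)[nH]1`) gives > 25000 nM which is a limit of the assay and not a number. Compound 2 (`CC(=O)Oc1ccc(/C=C/c2nc3ccccc3c(=O)[nH]2)c(OC(C)=O)c1`) gives > 25000 nM which is also a limit. Compound 3 (`COc1ccccc1/C=C/c1nc(Nc2ccccc2Cl)c2ccccc2n1`), which carries a methoxy group, gives > 25000 nM and this too is a limit. The whole set therefore comes down to the limit of > 25000 nM in this assay, at which 3 of the 3 values shown sit, and compound 1 has no readable number to start from.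

Compound 4 (`COc1ccccc1/C=C/c1nc2ccccc2c(=O)[nH]1`) changes compound 1 in one place: methyl in place of acetyl on an oxygen on an aromatic ring. In short, acetoxy gives way to methoxy, with methyl in place of acetyl on an oxygen on an aromatic ring. For the measured compounds named here, the only measured step that bears on this, a step that the two limits leave unreadable from compound 1 to compound 2, adds an acetoxy group and offers no size to carry over. With every measured compound at the limit, no step beyond the scatter is expected in this assay. The step expected is a number no higher from compound 1 to compound 4 (the limit leaves the size open) and it rests on that limit alone. For compound 4 the estimated value is 25000 nM with an expected range from 12000 nM to 50000 nM and a report of only a limit is likely.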

Compound 4, half-maximal inhibitory concentration: > 25000 nM
Compound 4 ended at the assay's limit (the forecaster's own chance of this, stated with the estimate: 80%); the middle value lies on the limit itself.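

No step can be read between compound 1 and compound 4, because both rest on the same limit, not on a number: the limit of > 25000 nM in this assay, at which 4 of the 4 values shown sit.

The compounds shown leave open how strongly any of them acts in this assay, and whether acetoxy or methoxy makes any difference there.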